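Cyano for chloro on compound 3

A few compounds are considered here, and "the series" means these few. Any claim that something is new, unique, unknown or untested is made for them only; others in the source may bear on it.

In a functional assay on THP-1 cells (Homo sapiens) for cytotoxicity, read by MTT assay, with a stated time of 24 h (a lower number here means a stronger inhibitor, a higher number a weaker inhibitor), compound 3 `COc1cc(/C=C2\CN(C)C/C(=C\c3ccc(Cl)cc3)C2=O)cc(OC)c1` gives 5860 nM and sits within the scatter of compound 1 `COc1ccc(/C=C2\CN(C)C/C(=C\c3ccccc3F)C2=O)cc1OC` with 11200 nM. Compound 2 `COc1cc(/C=C2\CN(C)C/C(=C\c3ccccc3F)C2=O)cc(OC)c1OC` gives 640 nM. The gap from compound 3 down to compound 2 lies beyond the scatter. Compound 4 `COc1cc(/C=C2\CN(C)C/C(=C\c3ccc(C#N)cc3)C2=O)cc(OC)c1` carries cyano in place of chloro on an aromatic carbon, para to a large group (cyano in place of chloro on an aromatic carbon). Among the measured compounds shown here, the only measured step of an 18-fold lower number from compound 1 to compound 2 (1.24 log units; beyond the scatter) is large but concerns methoxy in place of hydrogen on an aromatic carbon, so it does not speak to this exchange. In this assay no step beyond the scatter is therefore expected, the estimated change being a 1.3-fold lower number from compound 3 to compound 4 (0.11 log units; within the scatter) with no firm direction. Compound 4 is estimated at 4500 nM with a range of 1300 nM to 15000 nM overall.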

Compound 4, half-maximal inhibitory concentration: 940 nM
Estimate against measurement, compound 4: 4.8-fold (0.68 log units) above, outside the stated range (below it).
By their numbers in this assay, from the lowest: compounds 2 and 4 (each within the scatter of the next); then compounds 3 and 1 (each within the scatter of the next).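

In this assay, putting cyano in place of chloro gives a 6.2-fold lower number from compound 3 to compound 4 (0.79 log units; beyond the scatter) and so moves the number beyond the scatter. This shows that the group on this aromatic carbon, para to a large group, matters in this assay, which the earlier step, a methoxy change elsewhere, could not show. Nothing given here explains the step.

Going by these compounds, with only chloro and cyano at this place, how an amine or a carboxylic acid would behave there stays open. So does whether the step holds when the rest of the molecule changes.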